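A few compounds are considered here, and "the series" means these few. Any claim that something is new, unique, unknown or untested is made for them only; others in the source may bear on it.

Compound 3 `CCN(CC)c1ccc2cc(C(=O)NC3CC3)c(=O)oc2c1` reaches in a functional assay on HCT-116 cells (Homo sapiens) for cytotoxicity, read by MTT assay, with a stated time of 72 h (on this read-out higher numbers stand for weaker inhibition and lower numbers for stronger inhibition), only a limit of the assay, > 100000 nM. Compound 2 `CCN(CC)c1ccc2cc(C(=O)NCCO)c(=O)oc2c1` likewise gives only a limit in this assay, > 100000 nM. Compound 1 `O=C(NCCO)c1cc2ccc(OCc3ccc([N+](=O)[O-])cc3)cc2oc1=O`, built on the same core with other substituents, gives 33400 nM in this assay. Among the measured compounds shown here, the single measured step, a step that the two limits leave unreadable from compound 2 to compound 3, cannot be sized, because the limit of > 100000 nM in this assay, at which 2 of the 3 values shown sit, holds both of its ends. Compound 4 `CCN(CC)c1ccc2cc(C(=O)NN)c(=O)oc2c1` differs from compound 3 by amino in place of cyclopropyl on an amide-type nitrogen. For the measured compounds named here, no measured step follows this change, and the two limits give no direction to read from. Compound 4 is therefore expected to sit again at or near the limit, at 100000 nM (from 30000 nM to 300000 nM), and the expected step of a number no higher from compound 3 to compound 4 (the limit leaves the size open) is none beyond the scatter.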

Compound 4, half-maximal inhibitory concentration: 3360 nM
Compound 4: the middle estimate sits 30-fold (1.47 log units) above what was measured; measured number below the stated range.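

In this assay, the group on this amide-type nitrogen now makes a readable difference on the shared core, which the earlier pair could not show. Amino in place of cyclopropyl gives an at least 29-fold lower number from compound 3 to compound 4 (1.47 log units; beyond the scatter), and amino in place of 2-hydroxyethyl gives an at least 29-fold lower number from compound 2 to compound 4 (1.47 log units; beyond the scatter). Both steps start from a compound that sits at a limit of the assay: the limit of > 100000 nM in this assay, at which 2 of the 4 values shown sit.

On these data alone, how a methylamino or a hydroxyamino group on this nitrogen would read remains open. Also open, as far as these compounds go, is whether amino does the same on the core of compound 1, which gives 33400 nM with 2-hydroxyethyl.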